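Isobutyl for methoxyphenoxy on the core: permeability notes

The source may report more compounds than this note shows. Statements on the series, on what has been measured and on what is new or still open speak of the compounds shown alone.

Compound 1 `COc1ccc(Oc2ccc3c(NCCCNCc4cc(F)ccc4OC)ccnc3c2)cc1` carries a 4-methoxyphenoxy group on the shared core. In an ADME assay for permeability, using PAMPA, with a stated time of 30 min, at pH 7.4 (on this read-out higher numbers stand for higher permeability and lower numbers for lower permeability), compound 1 gives 317 10^-6 cm/s. Compound 2 `COc1ccc(Oc2ccc3c(NCCCNCc4cccc(OC)c4O)ccnc3c2)cc1` gives 317 10^-6 cm/s, and the step of no change at the digits printed from compound 1 to compound 2 (within the scatter) shows that exchanging the substituted benzyl group on the amine leaves the read-out where it was. Compound 3 `c1ccc(-c2ccc3c(NCCCNCc4ccco4)ccnc3c2)cc1` differs from compound 1 in several places. In this assay compound 3 gives 237 10^-6 cm/s. Its number sits within the scatter of compound 1 and compound 2, so all three measured compounds are indistinguishable on this read-out.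

Compound 4 `COc1ccc(F)cc1CNCCCNc1ccnc2cc(CC(C)C)ccc12` has not been measured. The change from compound 1 is isobutyl in place of 4-methoxyphenoxy on an aromatic carbon

For the measured compounds named here, no measured step touches this position on the core; the only single-site step, from compound 1 to compound 2, concerns the benzyl group and lies within the scatter, and compound 3, with a different group on the core as well as a different amine substituent, also stays within the scatter. The three numbers therefore give no ground to expect a shift beyond the scatter for compound 4, in either direction.

Compound 4 is accordingly expected to give about 300 10^-6 cm/s, within 150 10^-6 cm/s to 550 10^-6 cm/s, a step of a 1.1-fold lower number from compound 1 to compound 4 (0.02 log units; within the scatter) that is estimated to stay within the scatter.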

Compound 4, apparent permeability: 23 10^-6 cm/s
The estimate for compound 4 lay 13-fold (1.12 log units) above the measured number; measured number below the stated range.
By their numbers in this assay, from the lowest: compound 4; then compounds 3, 1 and 2 (each within the scatter of the next).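

For the compounds shown here, this position on the core is the first place where a single change moves the number in this assay beyond the scatter: the step reads a 14-fold lower number from compound 1 to compound 4 (1.14 log units; beyond the scatter) and is large. Going by these compounds alone, the only other single-site step, no change at the digits printed from compound 1 to compound 2 (within the scatter) on the benzyl group at the amine, stays within the scatter, so the read-out holds across that change but not across this one on the aromatic carbon of the core. The change replaces 4-methoxyphenoxy, which has a six-membered aromatic ring of carbon only and two hydrogen-bond acceptors, with isobutyl, which has no ring and no acceptors, and nothing available bears on why the number falls, so the step stands as an observation on the read-out alone.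

With a single pair at this position, the loss of the ring cannot be told apart from the loss of the oxygen atoms or from the smaller group size. As far as these compounds go, whether a plain phenoxy, a longer chain such as n-hexyl, or an amine on this carbon would sit with compound 1 or with compound 4 remains open.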